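Swapping the Amine Substituent: Compound 1 to Compound 4

The source may report more compounds than this note shows. Statements on the series, on what has been measured and on what is new or still open speak of the compounds shown alone.

Measured compounds in an ADME assay on MCF7-DOX cells (Homo sapiens) for cytotoxicity, read by MTT assay, with a stated time of 48 h; a lower number here means a stronger inhibitor, a higher number a weaker inhibitor:
- Compound 1, `COc1cc(OC)c(C(=O)/C=C/c2ccc(N(C)C)cc2)c(O)c1CC=C(C)C`, gives > 100000 nM, which is a limit of the assay rather than a number.
- Compound 2, `COc1cc(OC)c(C(=O)/C=C/c2cccc([N+](=O)[O-])c2)c(O)c1CC=C(C)C`, gives 57000 nM.
- Compound 3, `COc1cc(OC)c(C(=O)/C=C/c2cccc(F)c2)c(O)c1CC=C(C)C`, gives 45400 nM.

Compound 1 therefore stands only as a limit, while compound 2 and compound 3 each return a number. The change to compound 4, `COc1cc(OC)c(C(=O)/C=C/c2ccc(N3CCNCC3)cc2)c(O)c1CC=C(C)C`, is piperazin-1-yl in place of dimethylamino on an aromatic carbon. Going by the values given here, no measured step exchanges one group for another at this same position; the two steps that start from compound 1 replace the whole aryl group: an at least 1.7-fold lower number from compound 1 to compound 2 (0.24 log units; that floor lies within the scatter) and an at least 2.2-fold lower number from compound 1 to compound 3 (0.34 log units; beyond the scatter). Between the two substituted aryl compounds there is a 1.3-fold lower number from compound 2 to compound 3 (0.10 log units; within the scatter). These steps show only that moving away from the dimethylamino-bearing aryl group lowers the number modestly at best, and the limit of > 100000 nM in this assay, at which 1 of the 3 values shown sits, leaves the starting point itself open. A step no larger than the scatter, in either direction, is expected for an at least 1.1-fold lower number from compound 1 to compound 4 (0.04 log units; that floor lies within the scatter). Compound 4 is estimated at 90000 nM, within 35000 nM to 230000 nM.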

Compound 4, half-maximal inhibitory concentration: 57800 nM
Estimate against measurement, compound 4: 1.6-fold (0.19 log units) above; the range from low to high includes it.
By their numbers in this assay, from the lowest: compounds 3, 2 and 4 (each within the scatter of the next). At a limit, above all of these: compound 1.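

Compound 4 is the first compound shown that changes only the amine on this aryl group, without replacing the whole aryl group, and it returns a number where compound 1 gave only a limit. Exchanging dimethylamino for piperazin-1-yl, on an aromatic carbon para to a large group, gives an at least 1.7-fold lower number from compound 1 to compound 4 (0.23 log units; that floor lies within the scatter). The added ring and hydrogen-bond donor therefore leave the compound measurable, but the true size of the step stays unknown because only its floor can be read: the limit of > 100000 nM in this assay, at which 1 of the 4 values shown sits.

The compounds shown leave open whether the ring or its second nitrogen accounts for the measurable value. A morpholine ring or a piperazine ring carrying a methyl group on its second nitrogen, placed on this same carbon, would help separate those two features.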